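Taking the methoxy group off compound 1

The compounds below may be only part of what the source reports. "The series", "measured", "known", "first", "only" and "open" are said of these compounds alone.

Among the compounds with values here, in a functional assay on HOP-62 cells (Homo sapiens) for inhibition, read by sulforhodamine B assay, with a stated time of 48 h, tested at 10 uM (a lower number here means less inhibition of growth, a higher number more inhibition of growth at the concentration tested), compound 1 `COc1ccc(-c2nc3sc(-c4ccccc4)cn3n2)cc1` gives 49% and stands highest of the two compounds measured so far. Compound 2 `CC(=O)c1ccc(NC(=O)Cn2nc(C(F)(F)F)nc2N)cc1`, a compound with a clearly different structure, gives 9.94%. The gap between these two compounds lies beyond the usual scatter. Compound 3 `c1ccc(-c2nc3sc(-c4ccccc4)cn3n2)cc1` keeps the core of compound 1 and differs in one place: hydrogen in place of methoxy on an aromatic carbon para to a large group. Within the data shown here, no measured pair shows a change of this kind, so the expectation rests on judgement. Among the measured compounds shown here, only one group goes and the core stays, so much of the growth inhibition is expected to remain, with a moderate loss the likelier direction. In this assay the estimated step of a number 13 percentage points lower from compound 1 to compound 3 (beyond the scatter) is a modest drop, only a little beyond the scatter. The expected value for compound 3 is 36% with a range from 16% to 56% on this estimate.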

Compound 3, percent growth inhibition at one concentration: 33%
Estimate against measurement, compound 3: 3 percentage points above, and the stated range covers the measured number.
By their numbers in this assay, from the lowest: compound 2; then compound 3; then compound 1.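

Seen in this assay, the change from methoxy to hydrogen on an aromatic carbon para to a large group is a number 16 percentage points lower from compound 1 to compound 3 (beyond the scatter) and gives the first direct reading of what this position contributes. The methoxy group therefore adds to growth inhibition in this pair, but it is not essential: compound 3, which has no heavy atom at this place, still gives 33% at the concentration tested. No measurement available here explains the loss.

From the compounds shown here alone, with only methoxy and hydrogen compared, it remains open whether an amine, a hydroxyl group, a chlorine atom or a longer ether chain at the same place would match or exceed compound 1. Within the data shown here, it is also open whether changes elsewhere on the shared core would shift growth inhibition by a similar amount, as the only step so far lies at this one position.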